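From phenyl to thiophen-3-yl in a small inhibitor set

The source may report more compounds than this note shows. Statements on the series, on what has been measured and on what is new or still open speak of the compounds shown alone.

- compound 1 `CCOC(=O)c1cnc(NN2C(=O)CCC2=O)nc1C(F)(F)F`: 1600 nM
- compound 2 `CCOC(=O)c1cnc(N(C(=O)NC)N2C(=O)C=C(C)C2=O)nc1C(F)(F)F`: 590 nM
- compound 3 `CCOC(=O)c1cnc(NN2C(=O)C=C(C)C2=O)nc1-c1ccccc1`: 1200 nM

All three values come from a functional assay on Jurkat cells (Homo sapiens) for inhibition; a lower number here means a stronger inhibitor, a higher number a weaker inhibitor. Compound 3, at 1200 nM, cannot be told apart from compound 1, at 1600 nM, since the two numbers lie within the usual scatter of repeated measurements. Compound 2, at 590 nM, has a lower number than compound 3, and that gap lies just beyond the scatter.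

The next compound to be tested is compound 4 `CCOC(=O)c1cnc(NN2C(=O)C=C(C)C2=O)nc1-c1ccsc1`. It keeps the core of compound 3 but carries thiophen-3-yl in place of phenyl on an aromatic carbon, ortho to an ethoxycarbonyl group: thiophen-3-yl in place of phenyl on an aromatic carbon. The ethoxycarbonyl group and the rest of the molecule stay the same.

Among the compounds with values here, no two measured compounds differ in only one place, so the data do not show directly what this kind of ring exchange does in this assay. With no evidence for a direction, the expectation is a small step that stays within the scatter. The estimated change is a 1.1-fold lower number from compound 3 to compound 4 (0.04 log units; within the scatter). This expectation is anchored on compound 3 at 1200 nM, with a wide range to reflect how little the data can say. The expected value for compound 4 is 1100 nM, with an estimated range from 450 nM to 2600 nM.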

Compound 4, half-maximal inhibitory concentration: 200 nM
For compound 4 the middle estimate is 5.5-fold (0.74 log units) above the measured one; measured number outside the range, below it.
By their numbers in this assay, from the lowest: compound 4; then compound 2; then compounds 3 and 1 (each within the scatter of the next).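

In this assay, the aromatic carbon next to the ring nitrogen and ortho to an ethoxycarbonyl group proves sensitive to which aromatic ring it carries: the exchange gives a 6.0-fold lower number from compound 3 to compound 4 (0.78 log units; beyond the scatter) as thiophen-3-yl replaces phenyl. Within the data shown here, this is the first pair in the set that differs in only one place, so it is the first direct reading of any single change, and it shows that swapping one aromatic ring for another at this position need not be a neutral exchange on this core. Nothing available explains why the five-membered, sulfur-containing ring gives the lower number.

A single pair cannot separate the contribution of the sulfur atom from that of the smaller ring, and the compounds shown include no thiophen-2-yl, furan-3-yl or pyridine ring at this position that could begin to tell these apart. Going by these compounds, it also remains open whether the same exchange would give a step of similar size on a core carrying the succinimide ring of compound 1 or the methylurea-type substituent of compound 2, as one step on one core establishes no general pattern.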